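Sulfonylating the Ring Nitrogen of Compound 1

The compounds below may be only part of what the source reports. "The series", "measured", "known", "first", "only" and "open" are said of these compounds alone.

compound 1 `COc1ccc(-c2cc(=O)c3c(OC)cc(OC)cc3[nH]2)cc1`: > 31100 nM
compound 2 `COC(=O)c1cc(=O)c2cc(N)ccc2[nH]1`: > 33700 nM

Of the compounds shown here, two have been measured in a functional assay on HepG2 cells (Homo sapiens) for antiproliferative activity, with a stated time of 72 h; on this read-out higher numbers stand for an effect only at larger amounts of compound and lower numbers for an effect already at smaller amounts. For compound 1 the result is only a limit, > 31100 nM. For compound 2 the result is likewise only a limit, > 33700 nM. Among the measured compounds shown here, compound 1 therefore stands at a limit, and so does the one further value shown; no step between measured compounds can be drawn from them. Compound 3 `COc1ccc(-c2cc(=O)c3c(OC)cc(OC)cc3n2S(=O)(=O)c2ccc(F)cc2)cc1` has not yet been measured. It differs from compound 1 in one place: (4-fluorophenyl)sulfonyl in place of hydrogen on an aromatic nitrogen. The (4-fluorophenyl)sulfonyl group enters on the aromatic nitrogen of the fused system, where compound 1 carries a hydrogen. With compound 1 giving only a limit, the step in this assay cannot be sized from the data; a gain beyond the scatter is possible but unsupported. Compound 3 is expected to give about 20000 nM, estimated between 3000 nM and 60000 nM. The step of an at least 1.5-fold lower number from compound 1 to compound 3 (0.19 log units; that floor lies within the scatter) implied by this estimate is expected to be modest, and the result may itself remain a limit.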

Compound 3, half-maximal effective concentration: > 65500 nM
Compound 3: only a limit was reported; the forecaster's own chance of this, stated with the estimate: 60%; middle value at least 3.2-fold (0.51 log units) from the limit.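

In this assay compound 3 gives > 65500 nM, which is a limit. Among the compounds shown here, compound 1 gives > 31100 nM, also a limit, so no step between compound 1 and compound 3 can be read. Going by these compounds, whether (4-fluorophenyl)sulfonyl in place of hydrogen on the aromatic nitrogen changes the read-out at all remains open.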